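The source may hold more compounds than are shown below. What is called first, only, known or untested is meant among the compounds shown, and "the series" means these compounds.

Measured in an ADME assay on MCF-10A cells (Homo sapiens) for inhibition, with a stated time of 48 h (a lower number here means a stronger inhibitor, a higher number a weaker inhibitor), each value being a limit and not a number:
- Compound 1 `O=C(Nc1ccc(I)cc1)N1CCC[C@H]1c1nc(-c2ccccc2)no1`: > 50000 nM
- Compound 2 `O=C(Nc1ccc(OC(F)(F)F)cc1)N1CCC[C@H]1c1nc(-c2ccccc2)no1`: > 50000 nM
- Compound 3 `O=C(Nc1ccc(Cl)cc1)N1CCC[C@H]1c1nc(-c2ccccc2F)no1`: > 50000 nM

Compound 3 offers only a limit, > 50000 nM. The whole set shares this position: the limit of > 50000 nM in this assay, at which 3 of the 3 values shown sit. Compound 4 `O=C(Nc1ccc(Cl)cc1)N1CCC[C@H]1c1nc(-c2cccc(F)c2)no1` differs from compound 3 in one place, where 3-fluorophenyl stands in place of 2-fluorophenyl on an aromatic carbon: 3-fluorophenyl in place of 2-fluorophenyl on an aromatic carbon.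

For the measured compounds named here, the only measured step is a step that the two limits leave unreadable from compound 1 to compound 2. It exchanges iodo for trifluoromethoxy and leaves the phenyl group on the five-membered aromatic ring untouched, so it gives no size to carry over. Going by the values given here, no measured step moves the fluorine. With every value at one limit, no step beyond the scatter is expected in this assay, in either direction. The expected step is a number no higher from compound 3 to compound 4 (the limit leaves the size open). A report of only a limit is the most likely outcome for compound 4. For compound 4 the estimated value is 50000 nM, with an expected range from 20000 nM to 100000 nM.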

Compound 4, half-maximal inhibitory concentration: > 50000 nM
Compound 4: no number, only a limit; the forecaster's own chance of this, stated with the estimate: 85%; the middle value lies on the limit itself.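

In this assay, compound 3 and compound 4 each give only a limit and not a number, so the step between them cannot be read. The whole set stays at one position: the limit of > 50000 nM in this assay, at which 4 of the 4 values shown sit.

The compounds shown leave open how strongly any of them inhibits and whether 3-fluorophenyl and 2-fluorophenyl differ at all.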